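The source may report more compounds than this note shows. Statements on the series, on what has been measured and on what is new or still open speak of the compounds shown alone.

In a physicochemical assay for lipophilicity (a lower number here means a more polar compound, a higher number a more lipophilic compound), compound 1 `C#CCCOC(=O)/C=C(C)/C=C/CC(C)CCCC(C)(C)OC` gives 5.2. That is the lowest of the three numbers measured. Compound 2 `CCNC(=O)OC(C)(C)CCCC(C)C/C=C/C(C)=C/C(=O)OC(C)C` gives 6.06 in this assay, and compound 3 `CSC(=O)/C=C(C)/C=C/CC(C)CCCC(C)C` gives 7.44; both of these sit beyond the scatter from compound 1, compound 3 the furthest away. Compound 4 `CCCC(=O)/C=C(C)/C=C/CC(C)CCCC(C)(C)OC` has not yet been measured. It differs from compound 1 in one place: propyl in place of (but-3-yn-1-yl)oxy on a carbonyl carbon. With the ester oxygen gone and a shorter chain in its place, the expected step in this assay from compound 1 to compound 4 is a small one downward, a number 0.30 log units lower from compound 1 to compound 4 (within the scatter), close to the edge of the scatter. Compound 4 is therefore expected to give about 4.9, with a likely range from 4.3 to 5.5.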

Compound 4, partition coefficient: 5.61
The estimate for compound 4 lay 0.71 log units below the measured number; measured number outside the range, above it.
By their numbers in this assay, from the lowest: compound 1; then compound 4; then compound 2; then compound 3.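

In this assay, replacing (but-3-yn-1-yl)oxy with propyl on this carbonyl carbon gives a number 0.41 log units higher from compound 1 to compound 4 (beyond the scatter), so this one place on the shared core does change the number. The incoming propyl has fewer heavy atoms, no oxygen and no triple bond, yet compound 4 still reads higher. Because several features change at once, this pair cannot show which of them matters.

As far as these compounds go, whether an amine or a longer chain at the same carbonyl carbon would move the number further remains open. No measurement available here accounts for the step.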